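The compounds below may be only part of what the source reports. "The series", "measured", "known", "first", "only" and "open" are said of these compounds alone.

Measured compounds and values:
- Compound 1, `C=C1[C@@H](OC(C)=O)C[C@@H]2[C@](C)(CO[Si](C)(C)C(C)(C)C)[C@H](OC(C)=O)CC[C@@]2(C)[C@@H]1C[C@@H](Nc1ccccc1)C1=CCOC1=O`: 4840 nM
- Compound 2, `C=C1[C@@H](C/C=C2/C(=O)OC[C@H]2OC(C)=O)[C@]2(C)CC[C@@H](OC(C)=O)[C@@](C)(CO[Si](C)(C)C(C)(C)C)[C@H]2C[C@@H]1O`: 6960 nM
- Compound 3, `C=C1[C@@H](OC(C)=O)C[C@@H]2[C@](C)(COC=O)[C@H](OC(C)=O)CC[C@@]2(C)[C@@H]1C[C@@H](Nc1ccc(O)cc1)C1=CCOC1=O`: 18100 nM

All three were tested in a functional assay on MCF7 cells (Homo sapiens) for cytotoxicity, read by sulforhodamine B assay; a lower number here means a stronger inhibitor, a higher number a weaker inhibitor. Compound 3 gives the highest of the three numbers in this assay, and its distance to each of the other two lies beyond the scatter of repeated measurements, so compound 3 is the weakest inhibitor of the measured set. Compound 1, which carries a plain anilino group and a different protecting group on the primary alcohol, gives a clearly lower number than compound 3.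

The step to compound 4, `C=C1[C@@H](OC(C)=O)C[C@@H]2[C@](C)(COC=O)[C@H](OC(C)=O)CC[C@@]2(C)[C@@H]1C[C@@H](Nc1ccc(F)cc1)C1=CCOC1=O`, changes only one atom on the aromatic ring of compound 3: fluoro in place of hydroxy on an aromatic carbon. The hydroxy group that leaves is the only hydrogen-bond donor and acceptor at that position; fluoro brings neither. For the measured compounds named here, no measured pair in this set shows this exact exchange, so the size of the step can only be estimated. Compound 1 without any substituent on that ring sits well below compound 3, which suggests that the hydroxy group does not help here; a fluoro group is expected to behave closer to the unsubstituted ring. The step from compound 3 to compound 4 in this assay is therefore expected to be a 2.0-fold lower number from compound 3 to compound 4 (0.30 log units; within the scatter), a moderate fall in the number, beyond the scatter. Compound 4 is estimated to reach 9000 nM in this assay, within a range of 3500 nM to 22000 nM.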

Compound 4, half-maximal inhibitory concentration: 12400 nM
Estimate against measurement, compound 4: 1.4-fold (0.14 log units) below; the measured number falls inside the stated range.
By their numbers in this assay, from the lowest: compounds 1, 2, 4 and 3 (each within the scatter of the next, the first and the last beyond it).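

For the compounds shown here, this is the first pair in the set that differs in only one place, so the effect of a single group on the aromatic ring can be read directly. In this assay, fluoro in place of hydroxy gives a 1.5-fold lower number from compound 3 to compound 4 (0.16 log units; within the scatter), so at this position, para to a large group, a group with one hydrogen-bond donor and one acceptor can be exchanged for one with neither without a difference that stands clear of the usual scatter. No measurement at hand offers an explanation for this result.

One exchange at one position says little about other groups at that place, so a methoxy group, an amino group or a carboxylic acid there remains an open question. Going by these compounds, it is also open whether the same exchange would give a similar step with a different group on the primary alcohol.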